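Taking the methoxycarbonyl off compound 1

The source may report more compounds than this note shows. Statements on the series, on what has been measured and on what is new or still open speak of the compounds shown alone.

Of the compounds shown here, three have so far been measured in an ADME assay on MT4 cells (Homo sapiens) for cytotoxicity, read by MTT assay; on this read-out higher numbers stand for lower toxicity in this test and lower numbers for higher toxicity in this test. Compound 1 `COC(=O)c1ccc(NC(=O)CSc2nncnc2-c2cccc3ccccc23)c(Br)c1` gives 173000 nM and compound 2 `O=C(CSc1nncnc1-c1ccccc1Cl)Nc1ccccc1` gives 127000 nM, so these two share the top of the set, within the scatter of each other. Compound 3 `COC(=O)c1ccc(NC(=O)CSc2nncnc2-c2ccccc2Cl)c(Br)c1` gives 59000 nM, a clearly lower number than either.

Compound 4 `O=C(CSc1nncnc1-c1cccc2ccccc12)Nc1ccccc1Br` departs from compound 1 in one place: hydrogen in place of methoxycarbonyl on an aromatic carbon. Put simply, this is hydrogen in place of methoxycarbonyl on an aromatic carbon.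

Among the measured compounds shown here, no measured pair isolates this change. For the measured compounds named here, the only measured single change is a 2.9-fold lower number from compound 1 to compound 3 (0.47 log units; beyond the scatter), a modest step. It swaps naphthalen-1-yl for 2-chlorophenyl at another place, so it bears on the present question only indirectly, as a guide to how far one change can move this read-out. Compound 2 offers a further hint: it carries no methoxycarbonyl and still gives 127000 nM. Removing the group is therefore not expected to shift the number in either direction beyond the scatter, though the evidence is thin.

The estimated step is a 1.2-fold lower number from compound 1 to compound 4 (0.06 log units; within the scatter), which would stay within the scatter. Compound 4 is expected to give about 150000 nM, with an estimated range of 60000 nM to 320000 nM.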

Compound 4, half-maximal cytotoxic concentration: 87000 nM
Estimate against measurement, compound 4: 1.7-fold (0.24 log units) above; the range from low to high includes it.
By their numbers in this assay, from the lowest: compounds 3, 4, 2 and 1 (each within the scatter of the next, the first and the last beyond it).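

Until now, the role of the methoxycarbonyl on this aromatic carbon could only be inferred from compounds that differ elsewhere, but in this assay a measured pair now isolates it, with a 2.0-fold lower number from compound 1 to compound 4 (0.30 log units; within the scatter). With naphthalen-1-yl in place, this group of 4 heavy atoms can therefore give way to a single hydrogen without the read-out moving beyond the usual spread of repeat measurements, so this pair gives no sign that the methoxycarbonyl matters for the number in this test. No supporting measurement is available to explain this result or to give the group any particular role.

It remains open whether the same would hold with 2-chlorophenyl in place of naphthalen-1-yl; the compounds shown include no partner of compound 3 that differs from it only at this carbon. Also open, on these data alone, is how other groups on this carbon would read, such as a carboxylic acid, an amine or a longer ester chain, as hydrogen and methoxycarbonyl are the only two compared here on the naphthalen-1-yl compounds.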